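This account rests on a few compounds, and the source may have more. Where it says the series, first, only, none or still open, it means among the compounds named here.

Compound 1 `COc1ccc(/C(=C(/CCNC(=O)NCc2ccccc2)c2ccccc2)c2ccccc2)cc1` gives only a limit in a functional assay on MDA-MB-231 cells (Homo sapiens) for cytotoxicity, read by MTT assay, with a stated time of 72 h; a lower number here means a stronger inhibitor, a higher number a weaker inhibitor: > 50000 nM. Compound 2 `COc1ccc(/C(=C(/CCNC(=O)N2CCOCC2)c2ccccc2)c2ccccc2)cc1` gives 42800 nM in this assay. Compound 3 `COc1ccc(/C(=C(/CCNC(=O)C(=O)NCc2ccccc2)c2ccccc2)c2ccccc2)cc1` gives 11500 nM in this assay.

Compound 3 holds the lowest of the two actual numbers; its nearest neighbour is compound 2, and that step is a 3.7-fold lower number from compound 2 to compound 3 (0.57 log units; beyond the scatter). Compound 4 `COc1ccc(/C(=C(/CCNC(=O)C(=O)N2CCCCC2)c2ccccc2)c2ccccc2)cc1` differs from compound 3 by piperidin-1-yl in place of benzylamino on a carbonyl carbon. The nearest measured step is an at least 1.1-fold lower number from compound 1 to compound 2 (0.06 log units; that floor lies within the scatter), where a ring amine likewise replaced benzylamino on a carbonyl carbon. For compound 1 that step rests on a limit, (the limit of > 50000 nM in this assay, at which 1 of the 3 values shown sits), so its true size is not known. Nothing measured points to a large effect of this kind of swap. Only a small step, if any, is expected, a 1.4-fold higher number from compound 3 to compound 4 (0.14 log units; within the scatter). Compound 4 is estimated at 16000 nM, between 6000 nM and 45000 nM.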

Compound 4, half-maximal inhibitory concentration: > 50000 nM
Compound 4: no number, only a limit; the forecaster's own chance of this, stated with the estimate: 15%; at least 3.1-fold (0.49 log units) between middle value and limit.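

Replacing benzylamino with piperidin-1-yl on this carbonyl carbon is not the harmless swap that the earlier ring-amine step suggested: an at least 4.3-fold higher number from compound 3 to compound 4 (0.63 log units; beyond the scatter). The comparison with the morpholine compound gives only a floor inside the scatter, an at least 1.1-fold higher number from compound 2 to compound 4 (0.06 log units; that floor lies within the scatter), and the step between the two compounds that both end in limits cannot be read. Compound 4 itself gives only a limit: the limit of > 50000 nM in this assay, at which 2 of the 4 values shown sit.

On these data alone, whether the amide hydrogen or the aromatic ring of benzylamino carries the difference stays open. A cyclohexylmethylamino group on this carbonyl carbon would keep the hydrogen without the aromatic ring.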